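From 5-fluoropyridin-3-yl to 1,3-benzothiazol-5-yl on the shared core

This account rests on a few compounds, and the source may have more. Where it says the series, first, only, none or still open, it means among the compounds named here.

For the measured compounds named here, in an ADME assay (liver) for metabolic stability, with Liver microsome (Homo sapiens) as the target, using microsomes and NADPH, with a stated time of 30 min, tested at 1 uM (on this read-out lower numbers stand for slow clearance and higher numbers for fast clearance), compound 2 (`Nc1ccc(S(=O)(=O)N2CCN(c3ncc(C(O)(C(F)(F)F)C(F)(F)F)cc3-c3cncc(F)c3)CC2)cn1`) gives 24 mL.min-1.g-1, the only true number so far. Compound 1 (`CC(C)(O)C#Cc1cc(C(O)(C(F)(F)F)C(F)(F)F)cnc1N1CCN(S(=O)(=O)c2ccc(N)nc2)CC1`) gives < 14 mL.min-1.g-1, which is a limit of the assay and not a number. Going by the values given here, only one measured step bears on this place in the molecule: an at least 1.7-fold higher number from compound 1 to compound 2 (0.23 log units; that floor lies within the scatter). That step put 5-fluoropyridin-3-yl in place of 3-hydroxy-3-methylbut-1-yn-1-yl on an aromatic carbon.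

Compound 3 (`Nc1ccc(S(=O)(=O)N2CCN(c3ncc(C(O)(C(F)(F)F)C(F)(F)F)cc3-c3ccc4scnc4c3)CC2)cn1`) changes the same aromatic carbon, with 1,3-benzothiazol-5-yl in place of 5-fluoropyridin-3-yl on an aromatic carbon. The new group stands ortho to a large group and meta to a 2,2,2-trifluoro-1-hydroxy-1-(trifluoromethyl)ethyl group.

Among the compounds with values here, the expectation rests on compound 2 and its single guiding step, an at least 1.7-fold higher number from compound 1 to compound 2 (0.23 log units; that floor lies within the scatter), which offers no firm evidence of a shift at this place. The expected step is therefore small and upward, a 1.3-fold higher number from compound 2 to compound 3 (0.12 log units; within the scatter), and it may not clear the scatter. For compound 3 the estimated value in this assay is 32 mL.min-1.g-1, with an expected range from 15 mL.min-1.g-1 to 70 mL.min-1.g-1.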

Compound 3, intrinsic clearance in microsomes: 39 mL.min-1.g-1
Beside the measured number, compound 3's estimate is 1.2-fold (0.09 log units) below it; measured number inside the range.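

At this aromatic carbon, in this assay, exchanging one aromatic group for another gives a 1.6-fold higher number from compound 2 to compound 3 (0.21 log units; within the scatter), so 5-fluoropyridin-3-yl and 1,3-benzothiazol-5-yl, with its added five-membered ring, are not separated on this read-out. The new information lies in the comparison with the alkyne-bearing group, since replacing 3-hydroxy-3-methylbut-1-yn-1-yl with 1,3-benzothiazol-5-yl gives an at least 2.7-fold higher number from compound 1 to compound 3 (0.44 log units; beyond the scatter), whereas the floor of the earlier step to the 5-fluoropyridin-3-yl group lay within the scatter. That comparison has only a floor, as compound 1 stands at a limit of the assay and not at a number: the limit of < 14 mL.min-1.g-1 in this assay, at which 1 of the 3 values shown sits.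

Going by these compounds, the true size of the change from 3-hydroxy-3-methylbut-1-yn-1-yl to either aromatic group therefore remains open, as does whether the higher clearance numbers follow from the presence of an aromatic group at this carbon or from the loss of the alkyne with its tertiary alcohol. On these data alone, a plain phenyl ring, a morpholine or an alkyne ending in a primary alcohol at the same carbon could separate these readings, and how any of them would behave here remains unknown.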